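The compounds below may be only part of what the source reports. "The series", "measured", "known", "first", "only" and "open" are said of these compounds alone.

Working notes on the series. In a physicochemical assay for acid dissociation, compound 2 `O=[N+]([O-])c1ccc(Sc2ccc(NC(=S)Oc3ccc(O)cc3)cc2)cc1` gives 9.21, and compound 1 `CC(=O)Nc1ccc(OC(=S)Nc2ccc(Nc3ccc([N+](=O)[O-])cc3)cc2)cc1` gives 9.04; the two numbers lie within the scatter of each other, so neither is set apart. Compound 3 `CC(=O)Nc1ccc(OC(=S)Nc2ccc(Sc3ccc([N+](=O)[O-])cc3)cc2)cc1` is reached from compound 2 by the change (acetamido in place of hydroxy on an aromatic carbon), acetamido in place of hydroxy on an aromatic carbon. Among the compounds with values here, no measured pair shows this change on its own; the values of compound 1 and compound 2 suggest a step in this assay no larger than the scatter, if any, and downward if at all. For compound 3 the expected value is 9.05, within 8.7 to 9.4, an expected step of a number 0.16 log units lower from compound 2 to compound 3 (within the scatter).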

Compound 3, acid dissociation constant: 8.99
Compound 3: the middle estimate sits 0.06 log units above what was measured; the measured number falls inside the stated range.
By their numbers in this assay, from the lowest: compounds 3, 1 and 2 (each within the scatter of the next).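

In this assay, acetamido in place of hydroxy on an aromatic carbon, para to a large group, can now be read on its own (a number 0.22 log units lower from compound 2 to compound 3 (within the scatter)), and the step stays within the scatter. (4-Nitrophenyl)sulfanyl in place of (4-nitrophenyl)amino can also be read on its own (a number 0.05 log units lower from compound 1 to compound 3 (within the scatter)), and this step also stays within the scatter. Nothing available bears on the reason for either result. On these data alone, whether an amine or a carboxylic acid at the same place would give a step beyond the scatter remains open.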